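Working notes: methoxy on the benzoyl phenyl of compound 3

A few compounds are considered here, and "the series" means these few. Any claim that something is new, unique, unknown or untested is made for them only; others in the source may bear on it.

Measured in a functional assay on MCF7 cells (Homo sapiens) for antiproliferative activity; a lower number here means a stronger inhibitor, a higher number a weaker inhibitor:
- compound 1 `O=C(Nc1ccc(O)c2c(=O)cc(-c3ccccc3Cl)oc12)c1ccccc1`: 7100 nM
- compound 2 `O=C(Nc1ccc(O)c2c(=O)cc(-c3ccccc3Cl)oc12)c1ccc(Cl)c(Cl)c1`: 15000 nM
- compound 3 `O=C(Nc1c(O)cc(O)c2c(=O)cc(-c3ccccc3Cl)oc12)c1ccccc1`: 8500 nM

Compound 3, at 8500 nM, lies within the scatter of both compound 1 and compound 2. Next is compound 4 `COc1ccc(C(=O)Nc2c(O)cc(O)c3c(=O)cc(-c4ccccc4Cl)oc23)cc1`, with methoxy in place of hydrogen on an aromatic carbon, para to a large group: methoxy in place of hydrogen on an aromatic carbon. The nearest measured precedent changes the same phenyl: a 2.1-fold higher number from compound 1 to compound 2 (0.32 log units; beyond the scatter), a modest step, with 3,4-dichlorophenyl in place of phenyl. The hydroxy step, a 1.2-fold higher number from compound 1 to compound 3 (0.08 log units; within the scatter), concerns another place on the core. For the measured compounds named here, no methoxy compound has been measured, so only a small rise in this assay is expected, possibly none beyond the scatter. The estimated value for compound 4 is 10000 nM, with an expected range of 5000 nM to 20000 nM. The expected change is a 1.2-fold higher number from compound 3 to compound 4 (0.07 log units; within the scatter).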

Compound 4, half-maximal inhibitory concentration: 13000 nM
The estimate for compound 4 lay 1.3-fold (0.11 log units) below the measured number; the range from low to high includes it.
By their numbers in this assay, from the lowest: compounds 1, 3, 4 and 2 (each within the scatter of the next, the first and the last beyond it).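

In this assay, methoxy in place of hydrogen on the benzoyl phenyl, para to a large group, gives a 1.5-fold higher number from compound 3 to compound 4 (0.18 log units; within the scatter) on the core of compound 3. This place on the phenyl therefore accepts a single methoxy with no change beyond the scatter. No supporting data bear on this step, and no reason can be given for it.

As far as these compounds go, an amine or a carboxylic acid at this place remains open, as does a longer chain such as butoxy. Also open, from the compounds shown here alone, is whether methoxy gives a similar step on the core of compound 1.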